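The source may report more compounds than this note shows. Statements on the series, on what has been measured and on what is new or still open speak of the compounds shown alone.

Compound 1 `COc1cc(OC)c(C(=O)/C=C/c2ccccc2)c(OC)c1`: 6700 nM
Compound 2 `COc1cc(OC)c(C(=O)/C=C/c2ccccc2)c(OC)c1Cc1ccccc1O`: 4200 nM

Both values come from a functional assay on U-937 cells (Homo sapiens) for cytotoxicity, read by resazurin assay, with a stated time of 72 h; a higher number here means a weaker inhibitor, a lower number a stronger inhibitor. Among the measured compounds shown here, only two compounds have been measured so far, and compound 1 sits within the scatter of compound 2. That gives little basis for ranking either of them.

Compound 3 `COCOc1cc(OC)cc(OC)c1C(=O)/C=C/c1ccccc1` is not yet measured. It differs from compound 1 by methoxy in place of hydrogen on a saturated chain carbon bound to an oxygen on an aromatic ring, which is methoxy in place of hydrogen on a saturated chain carbon bound to an oxygen on an aromatic ring. Cut one bond further out, this reads methoxy to methoxymethoxy.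

For the measured compounds named here, the only measured step is a 1.6-fold lower number from compound 1 to compound 2 (0.20 log units; within the scatter), and it is a different change, 2-hydroxybenzyl in place of hydrogen on an aromatic carbon. It bears only indirectly, as a sign that one substitution on this core left the number within the scatter. Going by the values given here, no measured step covers the change itself, so no shift beyond the scatter is expected in this assay.

The expected step is a 1.1-fold lower number from compound 1 to compound 3 (0.05 log units; within the scatter), with no clear direction.

For compound 3 the estimated value is 6000 nM, with an expected range of 2500 nM to 14000 nM.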

Compound 3, half-maximal inhibitory concentration: 2500 nM
For compound 3 the middle estimate is 2.4-fold (0.38 log units) above the measured one; the range from low to high includes it.
By their numbers in this assay, from the lowest: compounds 3, 2 and 1 (each within the scatter of the next, the first and the last beyond it).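

In this assay, the change from methoxy to methoxymethoxy gives a 2.7-fold lower number from compound 1 to compound 3 (0.43 log units; beyond the scatter). Among the compounds shown here, this is the first step to clear the scatter, whereas the 2-hydroxybenzyl change on an aromatic carbon gave a 1.6-fold lower number from compound 1 to compound 2 (0.20 log units; within the scatter), so the number does respond to a change at this place, though only modestly. Nothing at hand accounts for the shift.

From the compounds shown here alone, two compounds differing from compound 1 at this place would help: it stays open whether the step follows the chain as such or the oxygen within it, which ethoxy or a longer chain such as methoxyethoxymethoxy could separate. Going by these compounds, it is also open whether an amine at the end of such a chain would keep, enlarge or lose the step.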